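This account rests on a few compounds, and the source may have more. Where it says the series, first, only, none or still open, it means among the compounds named here.

Working notes on the phenylethynyl benzamide hydroxamic acid series. Compound 1 `CC(C)C(NC(=O)c1ccc(C#Cc2ccccc2)cc1)C(=O)NO` carries the isopropyl side chain of the parent amino acid; compound 2 `O=C(NC1(C(=O)NO)CCSCC1)c1ccc(C#Cc2ccccc2)cc1` replaces the open chain by a sulfur-containing saturated ring. In a physicochemical assay for lipophilicity (a lower number here means a more polar compound, a higher number a more lipophilic compound), compound 1 reaches only a limit of the assay, > 3. In this assay compound 2 likewise reaches a limit, > 3. Both measured members thus sit at the same edge, as noted in the limit of > 3 in this assay, at which 2 of the 2 values shown sit, so no numbered step between them can be read. Compound 3 `CC(NC(=O)c1ccc(C#Cc2ccccc2)cc1)C(=O)NO` is the next member and differs from compound 1 by methyl in place of isopropyl on a saturated chain carbon bound to an amide-type nitrogen and a carbonyl carbon. Since the group that leaves is larger than the one that enters, a downward step beyond the scatter is expected in this assay, a number at least 0.20 log units lower from compound 1 to compound 3 (that floor lies within the scatter). For compound 3 the estimate in this assay is 2.8, expected to lie between 2.2 and 3.4.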

Compound 3, distribution coefficient: > 3
Compound 3: no number, only a limit (the forecaster's own chance of this, stated with the estimate: 40%); middle value at least 0.20 log units from the limit.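

Compound 3 also reaches only a limit in this assay, so no step from compound 1 to compound 3 can be read: the limit of > 3 in this assay, at which 3 of the 3 values shown sit.

The compounds shown leave open where each true distribution coefficient lies and whether methyl in place of isopropyl shifts it at all.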